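The source may report more compounds than this note shows. Statements on the series, on what has been measured and on what is new or still open speak of the compounds shown alone.

Series notes. Compound 1 `CCCC(C)C(=O)NCC(C)(C)CC1=C(O)C(=O)c2ccccc2C1=O`, compound 2 `CCCCCC(=O)NCC(C)(C)CC1=C(O)C(=O)c2ccccc2C1=O` and compound 3 `CCCCCCC(=O)NCC(C)(C)CC1=C(O)C(=O)c2ccccc2C1=O` share one core and differ only in the acyl chain on the amide nitrogen. In a functional assay on KB cells (Homo sapiens) for cytotoxicity, read by resazurin assay, with a stated time of 3 days (on this read-out higher numbers stand for weaker inhibition and lower numbers for stronger inhibition), compound 1 gives 47100 nM, compound 2 gives 40200 nM and compound 3 gives 28200 nM. All three measured steps are small: a 1.2-fold lower number from compound 1 to compound 2 (0.07 log units; within the scatter), a 1.7-fold lower number from compound 1 to compound 3 (0.22 log units; within the scatter) and a 1.4-fold lower number from compound 2 to compound 3 (0.15 log units; within the scatter). Compound 3 thus holds the lowest of the three numbers, yet its distance from compound 2 and from compound 1 stays within the scatter, so nothing separates the three compounds on this read-out.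

Compound 4 `CCCCCCC(C)C(=O)NCC(C)(C)CC1=C(O)C(=O)c2ccccc2C1=O` is the next member. Its change from compound 3 is 1-methylheptyl in place of hexyl on a carbonyl carbon. Among the compounds with values here, two measured steps bear on this: a 1.7-fold lower number from compound 1 to compound 3 (0.22 log units; within the scatter) sets a branched chain against hexyl, and a 1.4-fold lower number from compound 2 to compound 3 (0.15 log units; within the scatter) sets a shorter chain against hexyl; both remain within the scatter. The new chain is longer and branched, and the three compounds measured give no basis for a step beyond the scatter in this assay, in either direction. The expected step in this assay for compound 4 is a 1.1-fold lower number from compound 3 to compound 4 (0.05 log units; within the scatter). The estimate for compound 4 is 25000 nM, with a range from 10000 nM to 60000 nM.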

Compound 4, half-maximal inhibitory concentration: 23700 nM
Compound 4: middle estimate off by 1.1-fold (0.02 log units), on the high side, and the stated range covers the measured number.
By their numbers in this assay, from the lowest: compounds 4, 3, 2 and 1 (each within the scatter of the next).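

Working notes on the acyl position. In this assay, 1-methylheptyl in place of hexyl on a carbonyl carbon, with 8 heavy atoms entering and 6 leaving, gives a 1.2-fold lower number from compound 3 to compound 4 (0.08 log units; within the scatter) and so adds a longer branched chain to the series without a step beyond the scatter. The wider comparisons, a 1.7-fold lower number from compound 2 to compound 4 (0.23 log units; within the scatter) and a 2.0-fold lower number from compound 1 to compound 4 (0.30 log units; within the scatter), stay within the scatter as well, the second being the largest step in the series and showing that propyl in place of hydrogen on a saturated chain carbon, four bonds along the chain from a carbonyl carbon, still separates nothing on this read-out. No supporting measurement is available to explain this flat result.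

The compounds shown are all plain carbon chains at this position, so they leave open whether a chain ending in an amine or a carboxylic acid, or a phenyl ring on the carbonyl carbon, would move the number beyond the scatter. A much longer chain than 1-methylheptyl also remains an open case, as does any change to the shared core.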